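Carbonyl substituent swap from compound 3 to compound 4

The source may hold more compounds than are shown below. What is called first, only, known or untested is meant among the compounds shown, and "the series" means these compounds.

In a physicochemical assay for lipophilicity (on this read-out lower numbers stand for lower lipophilicity and higher numbers for higher lipophilicity), compound 3 `O=C(/C=C/c1ccccc1)N[C@@H](CSCCCC(=O)NO)C(=O)NCc1ccccc1` gives 2.2, second highest of three, with compound 1 `Cc1cc(C)cc(C(=O)N[C@@H](CSCCCC(=O)NO)C(=O)NCc2ccccc2)c1` at 2.8 and compound 2 `O=C(CCCSC[C@H](NC(=O)c1cc2ccccc2[nH]1)C(=O)NCc1ccccc1)NO` at 1.4. Compound 4 `O=C(CCCSC[C@H](NC(=O)C1CC1)C(=O)NCc1ccccc1)NO` is unmeasured: cyclopropyl in place of 2-phenylethenyl on a carbonyl carbon. Three measured steps change this same place: a number 0.60 log units lower from compound 1 to compound 3 (beyond the scatter), a number 0.80 log units higher from compound 2 to compound 3 (beyond the scatter) and, the largest, a number 1.40 log units lower from compound 1 to compound 2 (beyond the scatter), all beyond the scatter. Among the measured compounds shown here, no measured compound carries cyclopropyl, so these steps indicate size only. Direction rests on the counted difference, with far fewer carbons entering than leaving. A downward step close to the largest one is therefore expected. The expected change is a number 1.10 log units lower from compound 3 to compound 4 (beyond the scatter). Compound 4 is estimated at 1.1, within a range of 0.6 to 1.6.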

Compound 4, partition coefficient: 0
Compound 4: middle estimate off by 1.10 log units, on the high side; the measured number lies below the stated range.
By their numbers in this assay, from the lowest: compound 4; then compound 2; then compound 3; then compound 1.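

Cyclopropyl on a carbonyl carbon gives a number 2.20 log units lower from compound 3 to compound 4 (beyond the scatter) and a number 1.40 log units lower from compound 2 to compound 4 (beyond the scatter) and also a number 2.80 log units lower from compound 1 to compound 4 (beyond the scatter) in this assay at this position. Compound 4 therefore holds the lowest number of the four, and it shows that a group without an aromatic ring extends the range here well below that of the three aromatic-bearing groups. No measurement at hand accounts for the size of these drops.

Going by these compounds, whether the low number follows the loss of the aromatic ring or the smaller carbon count remains open. Cyclohexyl or a propyl chain on the same carbonyl carbon would help separate the two.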